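This account rests on a few compounds, and the source may have more. Where it says the series, first, only, none or still open, it means among the compounds named here.

Compound 3 `O=C(Nc1ccc(S(=O)(=O)Nc2ccccc2)cc1)c1ccc(Cl)cc1Br` sits at the top of the three measured numbers. In a functional assay on HEK293 cells for agonist activity at probable G-protein coupled receptor 27 (Homo sapiens), read by a luciferase reporter and beta-arrestin recruitment, with a stated time of 10 min (a higher number here means a larger maximal response, a lower number a smaller maximal response), compound 3 gives 123%. Compound 1 `Cc1cc(Cl)ccc1C(=O)Nc1ccc(S(=O)(=O)Nc2ccccc2)cc1` stands level with it: in this assay compound 1 gives 123%, and the two are within the scatter of each other. Compound 2 `O=C(Nc1ccc(S(=O)(=O)Nc2cccc(Cl)c2)cc1)c1ccc(Cl)cc1Cl` lies far beneath both; in this assay compound 2 gives 40%, a number well beyond the scatter from compound 3. Among the measured compounds shown here, compound 2 differs from compound 3 in two places, so no single step links them.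

Compound 4 `O=C(Nc1ccc(S(=O)(=O)Nc2ccccc2)cc1)c1ccc(Cl)cc1Cl` has not yet been measured. chloro in place of bromo on an aromatic carbon

For the measured compounds named here, the one measured step that bears on this change is the exchange of groups at the same aromatic carbon: no change at the digits printed from compound 1 to compound 3 (within the scatter). If a methyl and a bromo at that carbon give the same maximal response, a chloro there, which differs less from bromo than methyl does, is expected to leave the number essentially unchanged. Compound 2 also carries the 2,4-dichlorophenyl group, yet it differs from compound 4 in a second place as well, so its low value only widens the range below.

The expected step is a number 11 percentage points lower from compound 3 to compound 4 (beyond the scatter), within the scatter. Compound 4 is therefore estimated to give 112% in this assay, between 75% and 135%.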

Compound 4, largest response reached (Emax), in percent of the reference or control that the assay uses: 100%
Beside the measured number, compound 4's estimate is 12 percentage points above it; the range from low to high includes it.
By their numbers in this assay, from the lowest: compound 2; then compound 4; then compounds 1 and 3 (each within the scatter of the next).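

This carbon, ortho to a large group, turns out not to be indifferent to what sits on it: in this assay, going from 2-bromo-4-chlorophenyl to 2,4-dichlorophenyl gives a number 23 percentage points lower from compound 3 to compound 4 (beyond the scatter). Chloro in place of methyl gives a number 23 percentage points lower from compound 1 to compound 4 (beyond the scatter), so the match between methyl and bromo, no change at the digits printed from compound 1 to compound 3 (within the scatter), does not extend to chloro, and level numbers for two groups did not predict a third. Compound 4 also gives the first single-change link to compound 2: hydrogen in place of chloro at another aromatic carbon gives a number 60 percentage points higher from compound 2 to compound 4 (beyond the scatter), which ties a large part of the low number of compound 2 to that one chloro.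

Nothing at hand explains why chloro parts from methyl and bromo here. Still open, from the compounds shown here alone, is how a fluoro, a methoxy or an amine on this carbon would compare, and whether the step from bromo to chloro would keep its size in a compound that also carries the second chloro found in compound 2.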